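One Added Methyl on a Saturated Chain

The source may report more compounds than this note shows. Statements on the series, on what has been measured and on what is new or still open speak of the compounds shown alone.

Compound 1 `CCCCCC1(O)C(=O)Nc2ccc(Nc3ccc(OC)cc3)cc21` - 8000 nM
Compound 2 `CCCCC1(O)C(=O)Nc2ccc(Nc3ccc(F)cc3)cc21` - 6500 nM

Both values come from a functional assay on A549 cells (Homo sapiens) for antiproliferative activity, read by MTT assay, with a stated time of 48 h; a higher number here means a weaker inhibitor, a lower number a stronger inhibitor. Compound 2, at 6500 nM, lies within the scatter of compound 1, so neither stands apart. Compound 3 `CCCCCC1(O)C(=O)Nc2ccc(Nc3ccc(F)cc3)cc21` differs from compound 2 by methyl in place of hydrogen on a saturated chain carbon, four bonds along the chain from a saturated ring carbon. The two measured compounds differ in more than this one place, so they do not isolate the change. The chain of compound 3 also occurs in compound 1, at 8000 nM in this assay, and no step beyond the scatter is expected. Compound 3 is expected at 6000 nM (estimated range 3000 nM to 12000 nM).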

Compound 3, half-maximal inhibitory concentration: 5900 nM
Compound 3: middle estimate off by 1.0-fold (0.01 log units), on the high side; measured number inside the range.
By their numbers in this assay, from the lowest: compounds 3, 2 and 1 (each within the scatter of the next).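

In this assay, within the data shown here, methyl in place of hydrogen on a saturated chain carbon, four bonds along the chain from a saturated ring carbon, gives a 1.1-fold lower number from compound 2 to compound 3 (0.04 log units; within the scatter) and so reads this change alone for the first time. Fluoro in place of methoxy on an aromatic carbon gives a 1.4-fold lower number from compound 1 to compound 3 (0.13 log units; within the scatter) and thus also leaves these compounds within the scatter. No evidence bearing on these results is at hand. The compounds shown leave open whether a longer chain, or an amine in place of the added methyl, would move the number beyond the scatter.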